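A few compounds are considered here, and "the series" means these few. Any claim that something is new, unique, unknown or untested is made for them only; others in the source may bear on it.

Compound 1 `O=C(N/N=C/c1ccco1)c1cc(-c2ccccc2)nn1Cc1ccccc1` has the lowest of the two numbers recorded in a physicochemical assay on A549 cells for solubility, read by microscopy, with a stated time of 24 h (a higher number here means a weaker inhibitor, a lower number a stronger inhibitor), where compound 1 gives 8780 nM. Its nearest neighbour, compound 2 `O=C(N/N=C/c1ccco1)c1cc(-c2ccccc2)nn1Cc1ccc(Cl)nc1`, gives 19400 nM in this assay. The step of a 2.2-fold higher number from compound 1 to compound 2 (0.34 log units; beyond the scatter) is the only recorded one, and the two compounds differ at the saturated chain carbon bound to the aromatic nitrogen. Compound 3 `O=C(N/N=C/c1ccccc1O)c1cc(-c2ccccc2)nn1Cc1ccccc1` differs from compound 1 elsewhere: 2-hydroxyphenyl in place of furan-2-yl on a carbon with a double bond to nitrogen. Among the compounds with values here, no measured step touches this carbon with a double bond to nitrogen; the single recorded step, a 2.2-fold higher number from compound 1 to compound 2 (0.34 log units; beyond the scatter), concerns another part of the shared core and does not bear on the change to compound 3. The direction of the step is therefore open, and a move beyond the scatter cannot be assumed from what is known. Compound 3 is estimated to give 9000 nM in this assay, within 4000 nM to 20000 nM. The expected step is a 1.0-fold higher number from compound 1 to compound 3 (0.01 log units; within the scatter).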

Compound 3, half-maximal inhibitory concentration: 650 nM
The estimate for compound 3 lay 14-fold (1.14 log units) above the measured number; measured number below the stated range.
By their numbers in this assay, from the lowest: compound 3; then compound 1; then compound 2.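

In this assay, the carbon with a double bond to nitrogen turns out to be a place where a single change counts heavily: 2-hydroxyphenyl in place of furan-2-yl gives a 14-fold lower number from compound 1 to compound 3 (1.13 log units; beyond the scatter). This large step exceeds the modest one at the saturated chain carbon, a 2.2-fold higher number from compound 1 to compound 2 (0.34 log units; beyond the scatter), so of the two places changed so far, this one moves the number further. The change replaces a five-membered aromatic ring with a six-membered one of carbon only and brings in a hydrogen-bond donor, but nothing available shows which of these differences accounts for the step.

The compounds shown leave open whether plain phenyl at this carbon, or a phenyl ring bearing methoxy or an amine in place of the hydroxyl, would give a comparable step. They also leave open whether 6-chloropyridin-3-yl on the saturated chain carbon would shift the number in the same way with 2-hydroxyphenyl present.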